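Adding one methyl to compound 2: working notes

The source may report more compounds than this note shows. Statements on the series, on what has been measured and on what is new or still open speak of the compounds shown alone.

Compound 1 `O=C(Nc1ccn([C@H]2OCC=CC2=O)c(=O)n1)c1ccccc1` gives 72000 nM as a measured number
Compound 2 `C=C1[C@H](O)[C@H](O)CO[C@@H]1n1ccc(O)nc1=O` gives >= 800000 nM as a limit, not a number

Both readings come from a functional assay on HeLa cells (Homo sapiens), with a stated time of 3 days; a higher number here means a weaker inhibitor, a lower number a stronger inhibitor. Compound 2 has no number on this scale, and its >= 800000 nM is only a limit of the assay. Compound 3 `C=C1[C@H](O)[C@H](O)CO[C@@H]1n1cc(C)c(O)nc1=O` carries one change from compound 2: methyl in place of hydrogen on an aromatic carbon. Within the data shown here, no measured pair shows this change. In this assay no step beyond the usual scatter is expected, and no direction can be favoured. The expectation starts from compound 2 and its >= 800000 nM as the only reference point, and compound 3 may also be reported only as a limit. The expected move is a number no higher from compound 2 to compound 3 (the limit leaves the size open) and no more. For compound 3 the estimated value is 800000 nM within an expected range of 250000 nM to 1500000 nM in this assay.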

Compound 3, half-maximal inhibitory concentration: >= 800000 nM
Compound 3: no number, only a limit (the forecaster's own chance of this, stated with the estimate: 65%); the middle value lies on the limit itself.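

In this assay, compound 2 and compound 3 both stand as limits rather than numbers, so no step can be read between them: the limit of >= 800000 nM in this assay, at which 2 of the 3 values shown sit.

Going by these compounds, the effect of methyl in place of hydrogen on an aromatic carbon stays open, with no measured number on either side of this change.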